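Fluoro on the phenyl ring of compound 2

A few compounds are considered here, and "the series" means these few. Any claim that something is new, unique, unknown or untested is made for them only; others in the source may bear on it.

In a functional assay on HaCaT cells (Homo sapiens) for cytotoxicity, with a stated time of 48 h (a lower number here means a stronger inhibitor, a higher number a weaker inhibitor), compound 2 `COc1cc(OC)c(C(=O)/C=C/c2ccccc2)c(OC)c1` gives 7200 nM and compound 1 `COc1cc(OC)c(C(=O)/C=C/c2ccccc2SC)c(OC)c1` gives 7700 nM, two values within the scatter of each other. Compound 3 `COc1cc(OC)c(C(=O)/C=C/c2ccc(F)cc2)c(OC)c1` has fluoro in place of hydrogen on an aromatic carbon, para to a large group: fluoro in place of hydrogen on an aromatic carbon. Among the compounds with values here, the one measured step, a 1.1-fold lower number from compound 1 to compound 2 (0.03 log units; within the scatter), lies within the scatter, but it concerns methylsulfanyl and so bears only loosely on this change. The expected size of the new step, a 1.1-fold lower number from compound 2 to compound 3 (0.04 log units; within the scatter), stays within the scatter in this assay. Compound 3 is estimated at 6500 nM, with an expected range of 3000 nM to 14000 nM.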

Compound 3, half-maximal inhibitory concentration: 7600 nM
Compound 3: middle estimate off by 1.2-fold (0.07 log units), on the low side, and the stated range covers the measured number.
By their numbers in this assay, from the lowest: compounds 2, 3 and 1 (each within the scatter of the next).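

In this assay, fluoro on the phenyl ring, para to a large group, gives a 1.1-fold higher number from compound 2 to compound 3 (0.02 log units; within the scatter), so this change stays within the scatter, as the methylsulfanyl step did. Exchanging 2-(methylsulfanyl)phenyl for 4-fluorophenyl gives a 1.0-fold lower number from compound 1 to compound 3 (0.01 log units; within the scatter), which is also within the scatter, so all three compounds now lie within the scatter of one another. No supporting evidence accompanies this result. As far as these compounds go, whether any group at this place can move the number beyond the scatter stays open. An amine, a carboxylic acid or a longer chain in place of fluoro would test that.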